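Phenyl in Place of Methyl on a Ring Nitrogen

The compounds below may be only part of what the source reports. "The series", "measured", "known", "first", "only" and "open" are said of these compounds alone.

In an assay on membranes from brain for binding affinity to adenosine receptor A1 (Rattus norvegicus), read by radioligand binding, tested at 20 uM (on this read-out lower numbers stand for less inhibition and higher numbers for more inhibition at the one concentration tested (going by the name of the read-out)), compound 2 `Cn1c(=O)[nH]c2c(cnn2C)c1=N` gives 6%, the smaller of the two numbers measured, but only by a margin that lies within the usual scatter. Compound 1 `Cn1c(=O)[nH]c2c(cnn2-c2ccccc2F)c1=N` gives 8%, so the two cannot be told apart. Compound 3 `Cn1c(=O)[nH]c2c(cnn2-c2ccccc2)c1=N` has not yet been measured; it differs from compound 2 by phenyl in place of methyl on an aromatic nitrogen. Because compound 1, which carries a six-membered aromatic ring on the same nitrogen, gives 8%, the step is expected to stay within the scatter, a number 3 percentage points higher from compound 2 to compound 3 (within the scatter). Compound 3 is estimated to give 9%, ranging from 0% to 22%.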

Compound 3, a percentage reported as inhibition, at one concentration (the size of the read-out at that concentration, not a potency): 30%
Estimate against measurement, compound 3: 21 percentage points below; measured number outside the range, above it.
By their numbers in this assay, from the lowest: compounds 2 and 1 (each within the scatter of the next); then compound 3.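

In this assay phenyl in place of methyl on the aromatic nitrogen gives a number 24 percentage points higher from compound 2 to compound 3 (beyond the scatter) and so the number at this position depends on the group it carries. A six-membered aromatic ring there is not enough by itself: hydrogen in place of fluoro on an aromatic carbon of that ring gives a number 22 percentage points higher from compound 1 to compound 3 (beyond the scatter) and compound 1 cannot be told apart from compound 2. Nothing shown here explains either step.

Still open, on these data alone, is how a benzyl group or a longer chain on the same nitrogen would compare. Also open, as far as these compounds go, is what an amine or a methoxy group on the phenyl ring would do to the number.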